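Same Fluorine Shift on Two Related Cores

The compounds below may be only part of what the source reports. "The series", "measured", "known", "first", "only" and "open" are said of these compounds alone.

Four compounds share a sulfonyl group carrying a fluorophenyl ring, and differ in where the fluorine sits and in the core that holds the sulfonyl. Compound 1 `O=c1[nH]c2ccc(Cl)cc2n1S(=O)(=O)c1cccc(F)c1` and compound 3 `O=c1[nH]c2ccc(Cl)cc2n1S(=O)(=O)c1ccc(F)cc1` have one core; compound 2 `O=C1CN(S(=O)(=O)c2cccc(F)c2)c2cc(Cl)ccc2N1` and compound 4 `O=C1CN(S(=O)(=O)c2ccc(F)cc2)c2cc(Cl)ccc2N1` have another. How the two cores differ is not broken down here.

In an ADME assay on MT4 cells (Homo sapiens) for cytotoxicity, with a stated time of 5 days (a higher number here means that more compound is tolerated, a lower number that less compound is tolerated), compound 1 gives 128000 nM. Compound 3 reaches a limit of the assay rather than a number, namely >= 355000 nM. The change between them is 4-fluorophenyl in place of 3-fluorophenyl on a sulfonyl sulfur, and it brings an at least 2.7-fold higher number from compound 1 to compound 3 (0.44 log units; beyond the scatter). The size of this step is open at the top because of the limit of >= 355000 nM in this assay, at which 1 of the 3 values shown sits. Compound 2 gives 189000 nM in this assay, which lies within the usual scatter of the number for compound 1.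

Compound 4 is not yet measured. It differs from compound 2 by 4-fluorophenyl in place of 3-fluorophenyl on a sulfonyl sulfur. This is the same kind of change as between compound 1 and compound 3, though the surroundings are not identical: in compound 1 the sulfonyl sulfur is bound to an aromatic nitrogen, in compound 2 to a sulfonamide nitrogen in a ring. Given that compound 2 sits close to compound 1, and given the measured at least 2.7-fold higher number from compound 1 to compound 3 (0.44 log units; beyond the scatter), the step from compound 2 to compound 4 is expected to be a 2.2-fold higher number from compound 2 to compound 4 (0.35 log units; beyond the scatter). Compound 4 is therefore estimated at 420000 nM, with a plausible range from 200000 nM to 900000 nM, and a real chance that the assay again reports only a limit.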

Compound 4, half-maximal cytotoxic concentration: 172000 nM
Estimate against measurement, compound 4: 2.4-fold (0.39 log units) above; the whole stated range lies above it.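

In this assay, the same replacement of 3-fluorophenyl by 4-fluorophenyl gives a 1.1-fold lower number from compound 2 to compound 4 (0.04 log units; within the scatter), so on this core the two numbers cannot be told apart and the clear rise seen on the other core does not recur. The change therefore does not carry over unaltered in this series, and the result on the core of compound 1 would have been a poor guide to the result on the core of compound 2, as the two steps differ by more than repeated measurements would explain: the same change on two cores in this assay, an at least 2.7-fold higher number (0.44 log units; beyond the scatter) from compound 1 to compound 3 and a 1.1-fold lower number (0.04 log units; within the scatter) from compound 2 to compound 4, at least 3.0-fold (0.48 log units) apart, beyond the scatter of two such steps. With a single pair on each core, this does not show which feature of the cores decides the outcome or how far apart the two steps really are, and compound 3 gives a limit of the assay rather than a number: the limit of >= 355000 nM in this assay, at which 1 of the 4 values shown sits.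

From the compounds shown here alone, it remains open whether a methoxy group or a nitrile in place of the fluorine on the phenyl ring would also behave differently on the two cores. Going by these compounds, all four values come from a single cell assay, so whether the same split appears in any other measurement, or with an amine or a carboxylic acid added to either core, also remains unknown.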